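The source may report more compounds than this note shows. Statements on the series, on what has been measured and on what is new or still open speak of the compounds shown alone.

Within the data shown here, in an ADME assay on the whole organism (plasma) for pharmacokinetics, with Rattus norvegicus as the target, with a stated time of 24 h, at a dose of 10 mg/kg by the oral route (on this read-out lower numbers stand for lower exposure and higher numbers for higher exposure at the dose given), compound 2 `CCC[C@H](NC(=O)[C@@H]1[C@H]2[C@@H](CN1C(=O)[C@@H](NC(=O)NC1([C@H]3CCCS3(=O)=O)CCCCC1)C(C)(C)C)C2(C)C)C(=O)C(=O)NC1CC1` gives 203 ng.h/mL, the lower of the two numbers so far, while compound 1 `CC(C)(C)[C@H](NC(=O)NC1([C@H]2CCCCS2(=O)=O)CCCCC1)C(=O)N1C[C@@H]2[C@H]([C@H]1C(=O)N[C@@H](CCC1CC1)C(=O)C(=O)NC1CC1)C2(C)C` gives 574 ng.h/mL, a gap beyond the usual scatter. Compound 3 `CC(C)(C)[C@H](NC(=O)NC1([C@H]2CCCS2(=O)=O)CCCCC1)C(=O)N1C[C@@H]2[C@H]([C@H]1C(=O)N[C@@H](CCC1CC1)C(=O)C(=O)NC1CC1)C2(C)C` comes from compound 2 by one change: cyclopropyl in place of methyl on a saturated chain carbon, three bonds along the chain from an amide-type nitrogen and a carbonyl carbon. Among the measured compounds shown here, no measured pair isolates this change. Compound 1 also carries the 2-cyclopropylethyl chain and gives 574 ng.h/mL, so a rise seems likelier than a fall. The expected upward step, about the size of the scatter, is a 2.0-fold higher number from compound 2 to compound 3 (0.29 log units; within the scatter). The estimate for compound 3 is 400 ng.h/mL, with an expected range of 140 ng.h/mL to 1100 ng.h/mL.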

Compound 3, area under the concentration-time curve: 352 ng.h/mL
Compound 3: middle estimate off by 1.1-fold (0.06 log units), on the high side; low and high end bracket the measured number.
By their numbers in this assay, from the lowest: compounds 2, 3 and 1 (each within the scatter of the next, the first and the last beyond it).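

In this assay, cyclopropyl in place of methyl on a saturated chain carbon gives a 1.7-fold higher number from compound 2 to compound 3 (0.24 log units; within the scatter), so this change alone has no clear effect on exposure. Likewise, 1,1-dioxothiolan-2-yl in place of 1,1-dioxothian-2-yl on a saturated ring carbon gives a 1.6-fold lower number from compound 1 to compound 3 (0.21 log units; within the scatter), again no clear effect. Nothing available explains either result. Still open, from the compounds shown here alone, is how exposure would respond to an amine, a carboxylic acid or a longer chain on that saturated chain carbon.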